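Bromo on the indole and nitric oxide inhibition

The source may hold more compounds than are shown below. What is called first, only, known or untested is meant among the compounds shown, and "the series" means these compounds.

Measured compounds:
Compound 1 `COc1cc(/C(Cl)=C/C=C(\C#N)C(=O)c2c[nH]c3ccccc23)cc(OC)c1OC`: 73.3%
Compound 2 `COc1cc(/C(Cl)=C/C=C(\C#N)C(=O)c2c[nH]c3ccc(Br)cc23)cc(OC)c1OC`: 36.7%
Compound 3 `N#C/C(=C\C=C(/Cl)c1ccc(Br)cc1)C(=O)c1c[nH]c2ccccc12`: 76.7%

Of the compounds shown here, three have been tested in a functional assay for inhibition, read by Griess assay, with a stated time of 150 min, tested at 1 mM; a higher number here means more inhibition at the concentration tested (going by the name of the read-out), a lower number less inhibition. Compound 1 `COc1cc(/C(Cl)=C/C=C(\C#N)C(=O)c2c[nH]c3ccccc23)cc(OC)c1OC` gives 73.3% in this assay, and compound 2 `COc1cc(/C(Cl)=C/C=C(\C#N)C(=O)c2c[nH]c3ccc(Br)cc23)cc(OC)c1OC` gives 36.7%. The two differ in one place: bromo in place of hydrogen on an aromatic carbon. That change made a large step, a number 36.6 percentage points lower from compound 1 to compound 2 (beyond the scatter).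

Compound 3 `N#C/C(=C\C=C(/Cl)c1ccc(Br)cc1)C(=O)c1c[nH]c2ccccc12` gives 76.7% in this assay, a value that sits within the usual scatter of compound 1. The difference between the core of compound 3 and the core of compound 1 is not broken down here.

Compound 4 `N#C/C(=C\C=C(/Cl)c1ccc(Br)cc1)C(=O)c1c[nH]c2ccc(Br)cc12` has not yet been measured. It differs from compound 3 in one place: bromo in place of hydrogen on an aromatic carbon. This is the same change that was made from compound 1 to compound 2, in the same place, and among the compounds shown it occurs twice in all.

Because compound 1 lost so much in the step of a number 36.6 percentage points lower from compound 1 to compound 2 (beyond the scatter), a step of similar size is expected from compound 3 to compound 4, namely a number 34.7 percentage points lower from compound 3 to compound 4 (beyond the scatter). This expectation rests on a single earlier step, so it is held loosely. Compound 4 is therefore estimated to give 42% in this assay, with a likely range from 25% to 60%.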

Compound 4, a percentage reported as inhibition, at one concentration (the size of the read-out at that concentration, not a potency): 67.5%
For compound 4 the middle estimate is 25.5 percentage points below the measured one; measured number outside the range, above it.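

In this assay, the bromo change on the core of compound 3 gave a number 9.2 percentage points lower from compound 3 to compound 4 (within the scatter), so on this core no real loss can be claimed, unlike the clear loss seen on the core of compound 1. Within the data shown here, the change therefore cannot be treated as a fixed penalty that carries over unchanged from one core to the other: the same change on two cores in this assay, a number 36.6 percentage points lower (beyond the scatter) from compound 1 to compound 2 and a number 9.2 percentage points lower (within the scatter) from compound 3 to compound 4, 27.4 percentage points apart, beyond the scatter of two such steps This shows that the effect of bromo depends on the core it is placed on, but with only two pairs of compounds it does not show which feature of the cores matters, why they differ, or what would happen on a third core, and each number is a read-out at one concentration rather than a potency.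

Only hydrogen and bromo are shown at this aromatic carbon, so it remains open whether the dependence on the core is specific to bromo or would also appear with a fluoro group, an amine or a carboxylic acid in the same place. From the compounds shown here alone, it also remains open how the two cores would compare across a range of concentrations, which testing each compound at further concentrations could address.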